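Two Halogen Swaps on a Triazole-Linked Sulfonamide Scaffold

The source may hold more compounds than are shown below. What is called first, only, known or untested is meant among the compounds shown, and "the series" means these compounds.

Compound 1 `O=c1[nH]cc(S(=O)(=O)Nc2cccc(-c3cn(-c4ccc(F)cc4)nn3)c2)c(=O)[nH]1` and compound 3 `O=c1[nH]cc(S(=O)(=O)Nc2ccc(-c3cn(-c4ccc(F)cc4)nn3)cc2)c(=O)[nH]1` are built from the same atoms joined differently; the difference between the two cores is not broken down here. In a functional assay on OVCAR-3 cells (Homo sapiens) for antiproliferative activity, read by MTT assay, with a stated time of 24 h (on this read-out higher numbers stand for weaker inhibition and lower numbers for stronger inhibition), compound 1 gives > 20000 nM, which is a limit of the assay and not a number. In this assay compound 3 likewise gives > 20000 nM, again a limit of the assay. Compound 2 `O=c1[nH]cc(S(=O)(=O)Nc2cccc(-c3cn(-c4ccccc4Cl)nn3)c2)c(=O)[nH]1` carries 2-chlorophenyl in place of 4-fluorophenyl on an aromatic nitrogen and in this assay compound 2 gives 5370 nM. That change made an at least 3.7-fold lower number from compound 1 to compound 2 (0.57 log units; beyond the scatter), an at least modest step whose true size is hidden by the limit of > 20000 nM in this assay, at which 2 of the 3 values shown sit.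

Compound 4 `O=c1[nH]cc(S(=O)(=O)Nc2ccc(-c3cn(-c4ccccc4Cl)nn3)cc2)c(=O)[nH]1` has not yet been measured in this assay. It stands to compound 3 as compound 2 stands to compound 1: 2-chlorophenyl in place of 4-fluorophenyl on an aromatic nitrogen, the same change at the same place, described in identical terms for both pairs. The account rests on one measured step only, an at least 3.7-fold lower number from compound 1 to compound 2 (0.57 log units; beyond the scatter), taken on the core of compound 1, and on the shared limit of > 20000 nM in this assay, at which 2 of the 3 values shown sit, at which compound 3 also sits. On that basis compound 4 is expected to show an at least 2.5-fold lower number from compound 3 to compound 4 (0.39 log units; beyond the scatter). The estimate for compound 4 in this assay is 8000 nM, with a range from 3000 nM to 25000 nM, and it remains possible that compound 4 too is reported only as a limit.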

Compound 4, half-maximal inhibitory concentration: 4270 nM
Estimate against measurement, compound 4: 1.9-fold (0.27 log units) above; low and high end bracket the measured number.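

In this assay, 2-chlorophenyl in place of 4-fluorophenyl on an aromatic nitrogen gives an at least 4.6-fold lower number from compound 3 to compound 4 (0.67 log units; beyond the scatter), so the change points the same way on both cores shown, and the two steps can be set side by side: the same change on two cores in this assay, an at least 3.7-fold lower number (0.57 log units; beyond the scatter) from compound 1 to compound 2 and an at least 4.6-fold lower number (0.67 log units; beyond the scatter) from compound 3 to compound 4; the limit leaves it open whether they differ. This shows that the direction of the change carries over between these two cores: both compounds with 2-chlorophenyl give a measured number, both compounds with 4-fluorophenyl stand at a limit of the assay, and no compound shown goes against this. It does not show the true size of the change on either core, or whether that size carries over intact, and two compounds on each side make a small basis for any wider rule, since each step starts from a limit and not from a number: the limit of > 20000 nM in this assay, at which 2 of the 4 values shown sit.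

The compounds shown leave open whether the halogen itself or its place on the ring accounts for the change, as the two groups differ in both. They also leave open how this series would read with a plain phenyl, a benzyl group, or a phenyl ring bearing an amine or a carboxylic acid on the same nitrogen.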